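Swapping the Sulfur-Linked Ring for a Methyltetrazole

The source may hold more compounds than are shown below. What is called first, only, known or untested is meant among the compounds shown, and "the series" means these compounds.

Compound 2 `Cn1c(-c2ccc(NC(=O)CSc3nc4ccccc4s3)cc2)nc(-c2ccccc2)c1-c1ccccc1` gives 76.6% in a functional assay on MCF7 cells (Homo sapiens) for cytotoxicity, read by MTT assay, with a stated time of 24 h, tested at 80 ug/mL; a higher number here means a stronger effect of the compound at the concentration tested, a lower number a weaker effect. For the measured compounds named here, its sole measured neighbour, compound 1 `Cn1c(-c2ccc(NC(=O)CSc3nc4cc(Cl)ccc4o3)cc2)nc(-c2ccccc2)c1-c1ccccc1`, gives 69.1% in this assay. Compound 2 sits at the top of these two numbers, but the gap, a number 7.5 percentage points higher from compound 1 to compound 2 (within the scatter), is within the usual scatter.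

Compound 3 `Cn1nnnc1SCC(=O)Nc1ccc(-c2nc(-c3ccccc3)c(-c3ccccc3)n2C)cc1` differs from compound 2 by 1-methyl-1H-tetrazol-5-yl in place of 1,3-benzothiazol-2-yl on a sulfur. Going by the values given here, the only measured step that bears on this, a number 7.5 percentage points higher from compound 1 to compound 2 (within the scatter), also exchanged the ring on the sulfur and stayed within the scatter. The expected step of a number 10.6 percentage points lower from compound 2 to compound 3 (beyond the scatter) is therefore small, with no shift beyond the scatter anticipated. Compound 3 is estimated at 66%, between 45% and 82%.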

Compound 3, a percentage reported as activity, at one concentration (the size of the read-out at that concentration, not a potency): 77.7%
For compound 3 the middle estimate is 11.7 percentage points below the measured one, within the range that was stated.
By their numbers in this assay, from the lowest: compounds 1, 2 and 3 (each within the scatter of the next).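

In this assay, 1-methyl-1H-tetrazol-5-yl in place of 1,3-benzothiazol-2-yl on the sulfur gives a number 1.1 percentage points higher from compound 2 to compound 3 (within the scatter), and the same group in place of 5-chloro-1,3-benzoxazol-2-yl gives a number 8.6 percentage points higher from compound 1 to compound 3 (within the scatter). This position therefore accepts one five-membered aromatic ring as well as the larger fused groups, with no difference that can be told from scatter. Nothing measured here offers a reason for this.

The compounds shown leave open whether the sulfur could carry something other than an aromatic ring, such as a longer chain ending in an amine or a carboxylic acid. They also leave open whether these compounds would still match at other concentrations.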